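Estimating clearance after a change at the sulfonyl group

The compounds below may be only part of what the source reports. "The series", "measured", "known", "first", "only" and "open" are said of these compounds alone.

Compound 1 `N#Cc1ccc(S(=O)(=O)N2C[C@H](S(=O)(=O)c3ccc(Cl)cc3)[C@](O)(CO)C2)c(Cl)c1`: 49 mL/min/kg
Compound 2 `N#Cc1ccc(S(=O)(=O)N2C[C@H](S(=O)(=O)c3ccc(Cl)cn3)[C@](O)(CO)C2)c(Cl)c1`: 23 mL/min/kg

In an ADME assay on the whole organism (Rattus norvegicus, strain Sprague-Dawley) for pharmacokinetics, read by LC-MS, with a stated time of 30 min, at a dose of 1 mg/kg by the intravenous route (on this read-out lower numbers stand for slow clearance and higher numbers for fast clearance), compound 2 has the lower of the two numbers, at 23 mL/min/kg. Compound 3 `N#Cc1ccc(S(=O)(=O)N2C[C@H](S(=N)(=O)c3ccc(Cl)cc3)[C@](O)(CO)C2)c(Cl)c1` differs from it in one place on the shared core: a group of 10 heavy atoms (6 carbon, 1 nitrogen, 1 oxygen, 1 sulfur, 1 chlorine; one six-membered aromatic ring of carbon only) in place of a group of 10 heavy atoms (5 carbon, 1 nitrogen, 2 oxygen, 1 sulfur, 1 chlorine; one six-membered aromatic ring with 1 hetero atom), on a saturated ring carbon. For the measured compounds named here, the one measured step that bears on this is a 2.1-fold lower number from compound 1 to compound 2 (0.33 log units; beyond the scatter), with 5-chloropyridin-2-yl in place of 4-chlorophenyl on a sulfonyl sulfur. Compound 3 again carries an aromatic ring of carbon only, as does compound 1 at 49 mL/min/kg, so a modest move toward higher numbers is expected. Going by the values given here, the rest of the entering group appears in no measured compound, so the expectation stays loose. The estimated step is a 1.4-fold higher number from compound 2 to compound 3 (0.14 log units; within the scatter). For compound 3 the estimated clearance is 32 mL/min/kg, with an expected range of 15 mL/min/kg to 65 mL/min/kg.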

Compound 3, clearance: 52 mL/min/kg
Compound 3: middle estimate off by 1.6-fold (0.21 log units), on the low side, and the stated range covers the measured number.
By their numbers in this assay, from the lowest: compound 2; then compounds 1 and 3 (each within the scatter of the next).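

In this assay the cleanest reading is the step of a 1.1-fold higher number from compound 1 to compound 3 (0.03 log units; within the scatter): the aromatic ring of carbon only stays, one oxygen on the sulfur gives way to a nitrogen bearing a hydrogen, and the number stays within the scatter. The step of a 2.3-fold higher number from compound 2 to compound 3 (0.35 log units; beyond the scatter) changes the ring and the sulfur group together, yet it lands level with compound 1, so across these three compounds only the 5-chloropyridin-2-yl ring goes with a lower clearance, and the new sulfur group alone shows no shift. Nothing available explains these numbers.

The compounds shown leave open whether the 5-chloropyridin-2-yl ring would keep its lower clearance when joined to the new sulfur group. They also leave open what a methyl group on that nitrogen would do.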